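Replacing the aminomethylphenyl arm: compound 4 in context

A few compounds are considered here, and "the series" means these few. Any claim that something is new, unique, unknown or untested is made for them only; others in the source may bear on it.

Compounds measured so far:
compound 1, `CCCC[S+]([O-])c1sc2nc(-c3nccs3)cc(-c3ccc(CN)cc3)c2c1N`: 11.5 nM
compound 2, `CCCC[S+]([O-])c1sc2nc(-c3nccs3)cc(-c3ccc(CNC(C)=O)cc3)c2c1N`: 2.5 nM
compound 3, `CCCC[S+]([O-])c1sc2nc(-c3nccs3)cc(-c3ccc(COC(=O)CN(C)C)cc3)c2c1N`: 3.5 nM

In an assay for inhibition of 15-hydroxyprostaglandin dehydrogenase [NAD(+)] (Homo sapiens), read by fluorescence, with a stated time of 15 min, in the presence of a further agent that is not named here (a higher number here means a weaker inhibitor, a lower number a stronger inhibitor), compound 1 gives the highest of the three numbers, so it is the weakest inhibitor of the set. Compound 2 differs from compound 1 by acetyl in place of hydrogen on an amine nitrogen, and the step is a 4.6-fold lower number from compound 1 to compound 2 (0.66 log units; beyond the scatter). Compound 3 differs from compound 1 by (((dimethylamino)methyl)carbonyl)oxy in place of amino on a saturated chain carbon bound to an aromatic carbon, and that step is a 3.3-fold lower number from compound 1 to compound 3 (0.52 log units; beyond the scatter). Between compound 2 and compound 3 the step is a 1.4-fold higher number from compound 2 to compound 3 (0.15 log units; within the scatter).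

Compound 4, `CCCC[S+]([O-])c1sc2nc(-c3nccs3)cc(-c3cccc(CO)c3)c2c1N`, has not yet been measured. It differs from compound 1 by 3-(hydroxymethyl)phenyl in place of 4-(aminomethyl)phenyl on an aromatic carbon. Within the data shown here, both measured steps from compound 1 remove the free amine of the 4-(aminomethyl)phenyl group and lower the number modestly; compound 4 also loses that amine, gaining a hydroxymethyl in a different arrangement of the phenyl ring for which no measured step exists. The step from compound 1 to compound 4 is therefore expected to be a modest lowering, a 2.3-fold lower number from compound 1 to compound 4 (0.36 log units; beyond the scatter), though with a wide range. Compound 4 is estimated at 5 nM, between 1.5 nM and 18 nM.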

Compound 4, half-maximal inhibitory concentration: 4.3 nM
Beside the measured number, compound 4's estimate is 1.2-fold (0.07 log units) above it; low and high end bracket the measured number.
By their numbers in this assay, from the lowest: compounds 2, 3 and 4 (each within the scatter of the next); then compound 1.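

In this assay the step to compound 4 is a 2.7-fold lower number from compound 1 to compound 4 (0.43 log units; beyond the scatter) and it shows that this aromatic carbon on the shared core accepts more than the 4-substituted arms seen so far: the substituent can take a different arrangement on the phenyl ring, with an oxygen in place of the nitrogen, and the number still falls. The two arms match in heavy-atom, donor and acceptor counts and carry no net charge, and compound 4 now sits with compounds 2 and 3, each within the scatter of the next, so all three compounds lacking the amino group of compound 1 give lower numbers, and none of the four goes against this. Nothing measured here accounts for the step, so no reason can be given for it.

The compounds shown leave open how a 4-(hydroxymethyl)phenyl or a 3-(aminomethyl)phenyl arm would read, and with that which part of the change carries the step. Also open, going by these compounds, is whether a carboxylic acid or a longer chain on the phenyl ring would hold the number in this range.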